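The compounds below may be only part of what the source reports. "The series", "measured", "known", "first", "only" and "open" are said of these compounds alone.

Of the compounds shown here, three with a shared core have been tested in a functional assay on SK-OV-3 cells (Homo sapiens) for antiproliferative activity, read by MTT assay, with a stated time of 72 h; on this read-out lower numbers stand for stronger inhibition and higher numbers for weaker inhibition. Compound 1 `O=C(CCc1cccc2c1B(O)OC2)Nc1ccc(Br)cc1` gives 9200 nM, and compound 2 `O=C(CCc1cccc2c1B(O)OC2)Nc1ccc(I)cc1` gives 51000 nM.

Compound 3 `CC(C)(C)OC(=O)Nc1ccc(NC(=O)CCc2cccc3c2B(O)OC3)cc1` gives only a limit, > 100000 nM, and not a number.

Compound 4 `O=C(CCc1cccc2c1B(O)OC2)Nc1ccc([N+](=O)[O-])cc1` has not been measured. It carries nitro in place of (tert-butoxycarbonyl)amino on an aromatic carbon.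

Three measured changes at this same carbon bear on it. Iodo in place of bromo gave a 5.5-fold higher number from compound 1 to compound 2 (0.74 log units; beyond the scatter). (Tert-butoxycarbonyl)amino in place of bromo gave an at least 10-fold higher number from compound 1 to compound 3 (1.03 log units; beyond the scatter), and the same group in place of iodo gave an at least 1.9-fold higher number from compound 2 to compound 3 (0.29 log units; that floor lies within the scatter). So this carbon is sensitive to what it carries, yet none of these groups is nitro, and the true size of any step from a limit is unknown.

Removing the (tert-butoxycarbonyl)amino group is therefore expected to bring the number down, and the estimated step is an at least 2.8-fold lower number from compound 3 to compound 4 (0.45 log units; beyond the scatter).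

For compound 4 the expected value is 35000 nM, with an estimated range from 9000 nM to 100000 nM.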

Compound 4, half-maximal inhibitory concentration: 83000 nM
Estimate against measurement, compound 4: 2.4-fold (0.38 log units) below; the measured number falls inside the stated range.
By their numbers in this assay, from the lowest: compound 1; then compounds 2 and 4 (each within the scatter of the next). At a limit, above all of these: compound 3.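

In this assay, nitro in place of bromo gives a 9.0-fold higher number from compound 1 to compound 4 (0.96 log units; beyond the scatter), so compound 1 keeps the lowest number of the four, with all of its steps to the others beyond the scatter. Nitro in place of iodo gives a 1.6-fold higher number from compound 2 to compound 4 (0.21 log units; within the scatter), so the two values cannot be told apart on this read-out. Nitro in place of (tert-butoxycarbonyl)amino gives an at least 1.2-fold lower number from compound 3 to compound 4 (0.08 log units; that floor lies within the scatter). The size of that step cannot be read, because compound 3 carries only a limit of the assay: the limit of > 100000 nM in this assay, at which 1 of the 4 values shown sits.

From the compounds shown here alone, it remains open how a free amine or a chloro group at this same carbon would compare with bromo. Going by these compounds, it also remains open whether any group there would give a lower number than compound 1 does.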